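Taking the bromo group off compound 3

The source may report more compounds than this note shows. Statements on the series, on what has been measured and on what is new or still open speak of the compounds shown alone.

compound 1 `CN(C)C(=O)c1cc2cnc(Nc3ccc(NC(=O)C4(C(=O)Nc5cccc(O)c5)CC4)cc3)nc2n1C1CCCC1`: 77.5%
compound 2 `CN(C)C(=O)c1cc2cnc(Nc3ccc(NC(=O)C4(C(=O)Nc5ccccc5F)CC4)cc3)nc2n1C1CCCC1`: 70.2%
compound 3 `CN(C)C(=O)c1cc2cnc(Nc3ccc(NC(=O)C4(C(=O)Nc5ccc(Br)cc5)CC4)cc3)nc2n1C1CCCC1`: 27.6%

In a functional assay on NCI-H1299 cells (Homo sapiens) for inhibition, read by CCK-8 assay, with a stated time of 72 h, tested at 1 uM (a lower number here means less inhibition of growth, a higher number more inhibition of growth at the concentration tested), compound 3 gives 27.6%, the lowest of the three values, and it lies beyond the scatter from both of the others. Compound 4 `CN(C)C(=O)c1cc2cnc(Nc3ccc(NC(=O)C4(C(=O)Nc5ccccc5)CC4)cc3)nc2n1C1CCCC1` keeps everything else and carries phenyl where compound 3 carries 4-bromophenyl: hydrogen in place of bromo on an aromatic carbon.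

Among the measured compounds shown here, no measured step makes exactly this change, and plain phenyl is untested. The nearest evidence is the large a number 49.9 percentage points lower from compound 1 to compound 3 (beyond the scatter) and the large a number 42.6 percentage points lower from compound 2 to compound 3 (beyond the scatter), both of which bring in 4-bromophenyl. In contrast, a number 7.3 percentage points lower from compound 1 to compound 2 (within the scatter) stays within the scatter, so two different substituted phenyl groups give similar numbers.

A large upward step is therefore expected, recovering most of that drop, though with real uncertainty. The step expected is a number 34.4 percentage points higher from compound 3 to compound 4 (beyond the scatter). For compound 4 the estimated value is 62%, with an expected range of 40% to 82%.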

Compound 4, percent growth inhibition at one concentration: 71.2%
Compound 4: the middle estimate sits 9.2 percentage points below what was measured, and the stated range covers the measured number.
By their numbers in this assay, from the lowest: compound 3; then compounds 2, 4 and 1 (each within the scatter of the next).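

In this assay, replacing bromo with hydrogen gives a number 43.6 percentage points higher from compound 3 to compound 4 (beyond the scatter), so the low number of compound 3 goes with the bromo group itself and not with the phenyl ring that carries it. The plain phenyl group also matches the two other substituted rings, with a number 1 percentage points higher from compound 2 to compound 4 (within the scatter) and a number 6.3 percentage points lower from compound 1 to compound 4 (within the scatter), so hydrogen, the fluoro of 2-fluorophenyl and the hydroxy of 3-hydroxyphenyl cannot be told apart here. Among these four compounds only 4-bromophenyl stands apart, and no evidence given here bears on why.

The compounds shown leave open whether a chloro, methyl or methoxy group para to the large group would bring a similar drop, or whether it is peculiar to bromo. They also leave open whether bromo elsewhere on the ring, as in 3-bromophenyl, would lower the number at all.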